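Quinoline in Place of Thiadiazole on the Amide Carbonyl

The source may hold more compounds than are shown below. What is called first, only, known or untested is meant among the compounds shown, and "the series" means these compounds.

Among the compounds with values here, compound 1 `O=C(NC1CCCCC1)NS(=O)(=O)N1CCC(CCNC(=O)c2csnn2)CC1` stands lowest of the two numbers measured so far: in a functional assay on the whole organism (blood) with Rattus norvegicus as the target, with stated times of 24 h and 1 h, at a dose of 5 mg/kg by the intraperitoneal route (a higher number here means a stronger effect of the compound at the dose given, a lower number a weaker effect), compound 1 gives 19%, while compound 2 `O=C(NC[C@@H]1C[C@@H]2C=C[C@@H]1C2)NS(=O)(=O)N1CCC(CCNC(=O)c2cc(Cl)ccn2)CC1` gives 32%, a gap beyond the usual scatter. Compound 3 `O=C(NC1CCCCC1)NS(=O)(=O)N1CCC(CCNC(=O)c2ccnc3ccccc23)CC1` differs from compound 1 in a single place: quinolin-4-yl in place of 1,2,3-thiadiazol-4-yl on a carbonyl carbon. Within the data shown here, no pair of measured compounds shares only this change, so its effect is not known from the data. A modest upward step is expected, and the step of a number 8 percentage points higher from compound 1 to compound 3 (within the scatter) may still fall within the scatter. For compound 3 the estimate in this assay is 27%, with a likely range from 10% to 48%.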

Compound 3, a percentage reported as activity, at one dose (the size of the read-out at that dose, not a potency): 16%
Compound 3: middle estimate off by 11 percentage points, on the high side, and the stated range covers the measured number.
By their numbers in this assay, from the lowest: compounds 3 and 1 (each within the scatter of the next); then compound 2.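

In this assay, replacing 1,2,3-thiadiazol-4-yl with quinolin-4-yl on a carbonyl carbon gives a number 3 percentage points lower from compound 1 to compound 3 (within the scatter). Here, a group of 10 heavy atoms with two fused rings takes the place of one with 5 heavy atoms and a single ring, with no difference beyond the scatter. No measurement at hand explains this result. Still open, going by these compounds, is whether a phenyl ring or a carboxylic acid on this carbonyl carbon would give a clearly different number, and whether quinolin-4-yl would behave alike on another core.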